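The source may hold more compounds than are shown below. What is called first, only, known or untested is meant among the compounds shown, and "the series" means these compounds.

In a functional assay on MCF7 cells (Homo sapiens) for antiproliferative activity, read by MTT assay, with a stated time of 72 h (a higher number here means a weaker inhibitor, a lower number a stronger inhibitor), compound 1 (`CCCCCCCCCCNC[C@@H]1OC[C@H](N)[C@@H]1O`) gives 34200 nM and compound 3 (`CCCCCCCCCCCCNC[C@@H]1OC[C@H](N)[C@@H]1O`) gives 1800 nM in the same test. Compound 2 (`CCCCCCCCCCCCNC[C@@H]1OC[C@H](N)[C@H]1O`) gives 12600 nM as the middle of the three numbers. Compound 4 (`CCCCCCCNC[C@@H]1OC[C@H](N)[C@H]1O`) follows from compound 2 by shortening the chain (hydrogen in place of pentyl on a saturated chain carbon, seven bonds along the chain from an amine nitrogen) with the configuration of compound 2 kept. Among the measured compounds shown here, the closest measured guide is the chain step (a 19-fold lower number from compound 1 to compound 3 (1.28 log units; beyond the scatter)), which was seen only in the configuration of compound 3. Read in reverse, it points to a higher number on shortening, and more chain carbons leave here than in that step. The configuration step (a 7.0-fold lower number from compound 2 to compound 3 (0.85 log units; beyond the scatter)) and the fact that compounds 2 and 3 differ only in the configuration as drawn show that the two configurations are not equivalent, so the chain step may not carry over at full size. A large rise is therefore expected in this assay (a 7.1-fold higher number from compound 2 to compound 4 (0.85 log units; beyond the scatter)) for this change. For compound 4 the estimated value is 90000 nM with an expected range from 30000 nM to 270000 nM in this test.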

Compound 4, half-maximal inhibitory concentration: > 128000 nM
Compound 4 gave a limit, no number; the forecaster's own chance of this, stated with the estimate: 35%; at least 1.4-fold (0.15 log units) between middle value and limit.
By their numbers in this assay, from the lowest: compound 3; then compound 2; then compound 1. At a limit, above all of these: compound 4.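

In this assay compound 4 gives > 128000 nM, which is a limit and not a number. Hydrogen in place of pentyl on a saturated chain carbon, seven bonds along the chain from an amine nitrogen, raises the number in the configuration of compound 2, with an at least 10-fold higher number from compound 2 to compound 4 (1.00 log units; beyond the scatter). Among the compounds shown here, the earlier chain step, a 19-fold lower number from compound 1 to compound 3 (1.28 log units; beyond the scatter), was seen only in the configuration of compound 3, so chain length now shows an effect in both configurations.

On these data alone, the full size of the new step stays open, and it cannot be set against the earlier chain step, because only a limit stands for compound 4: the limit of > 128000 nM in this assay, at which 1 of the 4 values shown sits. Also open, as far as these compounds go, is how the chain of compound 4 reads in the configuration of compound 3, and how a longer chain reads in either configuration.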